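The source may report more compounds than this note shows. Statements on the series, on what has been measured and on what is new or still open speak of the compounds shown alone.

Notes on the series. Compound 1 `CCOC(=O)CCO/N=C(/c1ccc(OC)c(OC)c1OC)c1cccc2ccccc12` and compound 2 `COc1ccc(/C(=N/OC(C)=O)c2cccc3ccccc23)c(OC)c1OC` share the core and differ only at the oxime oxygen; in a functional assay on HCT-116 cells (Homo sapiens) for inhibition, read by sulforhodamine B assay, with a stated time of 48 h (a higher number here means a weaker inhibitor, a lower number a stronger inhibitor), compound 1 gives 10000 nM and compound 2 gives 4980 nM, and the step of a 2.0-fold lower number from compound 1 to compound 2 (0.30 log units; within the scatter) places the two within the scatter of each other. Compound 3 `COc1ccc(C(O)(C/C=C\c2ccccc2)c2cccc3ccccc23)c(OC)c1OC` is recorded in this assay only as a limit, > 20000 nM, and the limit of > 20000 nM in this assay, at which 1 of the 3 values shown sits, marks it as such. Compound 4 `COc1ccc(/C(=N/O)c2cccc3ccccc23)c(OC)c1OC` is not yet measured; it differs from compound 2 by hydrogen in place of acetyl on an oxygen. Among the measured compounds shown here, the only measured step bearing on this position, a 2.0-fold lower number from compound 1 to compound 2 (0.30 log units; within the scatter), stayed within the scatter, so no step beyond the scatter is expected here, a 1.0-fold higher number from compound 2 to compound 4 (0.00 log units; within the scatter). Compound 4 is therefore estimated at 5000 nM in this assay, between 2000 nM and 15000 nM.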

Compound 4, half-maximal inhibitory concentration: 5880 nM
The estimate for compound 4 lay 1.2-fold (0.07 log units) below the measured number, and the stated range covers the measured number.
By their numbers in this assay, from the lowest: compounds 2, 4 and 1 (each within the scatter of the next). At a limit, above all of these: compound 3.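

The steps, a 1.2-fold higher number from compound 2 to compound 4 (0.07 log units; within the scatter) and a 1.7-fold lower number from compound 1 to compound 4 (0.23 log units; within the scatter), show that in this assay the group on this oxygen can be reduced to plain hydrogen without leaving the scatter. Hydrogen, acetyl and 2-(ethoxycarbonyl)ethyl therefore read alike here, and neither of the two larger groups is needed for a number of this size.

From the compounds shown here alone, whether an amine, a carboxylic acid or a longer alkyl chain on this oxygen would give a step beyond the scatter stays open. Nothing at hand speaks to why these three numbers lie so close together.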